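From Hydroxy to Dimethylamino on a Saturated Chain

The source may hold more compounds than are shown below. What is called first, only, known or untested is meant among the compounds shown, and "the series" means these compounds.

In a functional assay on HCT-8 cells (Homo sapiens) for antiproliferative activity, read by MTT assay, with a stated time of 48 h (on this read-out higher numbers stand for weaker inhibition and lower numbers for stronger inhibition), compound 1 `COc1ccc(C(=O)c2ccc3c(c2)C=CC(C)(C)O3)c(NC(=O)CO)c1` gives 250 nM. Compound 2 `C=C(c1cc(OC)c(OC)c(OC)c1)c1ccc(OC)cc1NC(=O)CO` gives 40 nM, the lower of the two numbers, and the gap between them lies beyond the scatter. Compound 3 `C=C(c1cc(OC)c(OC)c(OC)c1)c1ccc(OC)cc1NC(=O)CN(C)C` carries dimethylamino in place of hydroxy on a saturated chain carbon bound to a carbonyl carbon. Within the data shown here, no measured pair of compounds shows this change, so any expectation is loose. A modest weakening is expected, an estimated step of a 1.8-fold higher number from compound 2 to compound 3 (0.24 log units; within the scatter) that may stay within the scatter. For compound 3 the expected value is 70 nM, with an estimated range of 15 nM to 300 nM.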

Compound 3, half-maximal inhibitory concentration: 340 nM
For compound 3 the middle estimate is 4.9-fold (0.69 log units) below the measured one, outside the stated range (above it).
By their numbers in this assay, from the lowest: compound 2; then compounds 1 and 3 (each within the scatter of the next).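

Placing dimethylamino in place of hydroxy on a saturated chain carbon bound to a carbonyl carbon is not a neutral change in this assay: it gives an 8.5-fold higher number from compound 2 to compound 3 (0.93 log units; beyond the scatter). Among these compounds, this is the first single-place comparison, and it shows that the number responds to the group at this position. No available evidence accounts for the size of this step. Still open, on these data alone, is how a primary amine, a carboxylic acid or a longer chain would behave at this position. As far as these compounds go, whether dimethylamino would give a similar step on the core of compound 1 also remains open.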